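Trading Bromo for Aminomethyl at the Benzamide End

The source may hold more compounds than are shown below. What is called first, only, known or untested is meant among the compounds shown, and "the series" means these compounds.

Compound 3, `O=C(COc1ccc2c(=O)ccoc2c1)Nc1cccc(NC(=O)c2ccc(Br)cc2)c1`, is the reference point of this account. In an assay on isolated protein for inhibition of Rho-associated protein kinase 2 (Homo sapiens), read by scintillation counting, radiometric assay and 33P incorporation, with a stated time of 40 min, in the presence of a further agent that is not named here (a higher number here means a weaker inhibitor, a lower number a stronger inhibitor), compound 3 gives 49 nM, the lowest of the two numbers recorded so far. Compound 2, `Cc1coc2cc(OCC(=O)Nc3cccc(NC(=O)c4ccc(N(C)C)cc4)c3)ccc2c1=O`, gives 2150 nM in this assay, and the gap between the two lies well beyond the scatter of repeated measurements. Compound 1, `CN(C)c1ccc(C(=O)Nc2cccc(NC(=O)COc3ccc4occc(=O)c4c3)c2)cc1`, returns > 10000 nM in this assay, which is a limit of the assay and not a number (the limit of > 10000 nM in this assay, at which 1 of the 3 values shown sits).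

Compound 4, `NCc1ccc(C(=O)Nc2cccc(NC(=O)COc3ccc4c(=O)ccoc4c3)c2)cc1`, has not yet been measured. It differs from compound 3 in a single place: aminomethyl in place of bromo on an aromatic carbon. Among the compounds with values here, no pair of measured compounds shows this exchange, so nothing already measured fixes its size or direction. The expectation is a modest loss of potency, with the step from compound 3 to compound 4 expected to be a 2.7-fold higher number from compound 3 to compound 4 (0.42 log units; beyond the scatter), beyond the scatter but far short of the gap to compound 2. Compound 4 is accordingly estimated at 130 nM in this assay, with a plausible range from 25 nM to 700 nM.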

Compound 4, half-maximal inhibitory concentration: 66 nM
For compound 4 the middle estimate is 2.0-fold (0.29 log units) above the measured one; low and high end bracket the measured number.
By their numbers in this assay, from the lowest: compounds 3 and 4 (each within the scatter of the next); then compound 2. At a limit, above all of these: compound 1.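

In this assay, the exchange of bromo for aminomethyl gives a 1.3-fold higher number from compound 3 to compound 4 (0.13 log units; within the scatter). Within the data shown here, neither of the earlier compounds could show this, since no measured pair differed in one place only. The step shows that, on this aromatic carbon para to a large group, the 4-bromophenyl can give way to a 4-(aminomethyl)phenyl without a change beyond the usual scatter, even though bromo is a single atom with no hydrogen-bond donor or acceptor and aminomethyl is larger and carries one of each. Nothing measured here explains why the two groups read alike.

The compounds shown leave open how far this tolerance extends at the same position, for instance to a longer aminoethyl chain, a carboxylic acid or a methoxy group, any of which would test whether the result is specific to bromo and aminomethyl or holds more broadly. They also leave open whether aminomethyl would behave the same way on a core that differs elsewhere, such as the core of compound 2, which carries an added methyl group.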